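Swapping the linker in a melanocortin receptor 4 binder

The source may hold more compounds than are shown below. What is called first, only, known or untested is meant among the compounds shown, and "the series" means these compounds.

Measured compounds:
- Compound 1, `CCN(CC)CCCC(C)/N=C(/N)NC(=O)c1cccc(F)c1OCc1cc(Br)ccc1OC`: 900 nM
- Compound 2, `COc1ccc(Br)cc1CCc1c(F)cccc1C(=O)/N=C(\N)NCCN1CCCC1`: 190 nM
- Compound 3, `COc1ccc(Br)cc1CCc1c(F)cccc1C(=O)/N=C(\N)NCCCN1CCCCC1`: 3.2 nM

All three were tested in an assay for binding affinity to Melanocortin receptor 4 (Homo sapiens); a lower number here means a stronger inhibitor, a higher number a weaker inhibitor. Compound 1 has the highest number of the three; the nearest to it is compound 2, and the furthest is compound 3, both with lower numbers that lie beyond the scatter.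

The step from compound 1 to compound 4, `CCN(CC)CCCC(C)/N=C(/N)NC(=O)c1cccc(F)c1CCc1cc(Br)ccc1OC`, changes the bridge between the two aromatic rings: a group of 11 heavy atoms (9 carbon, 1 oxygen, 1 bromine; one six-membered aromatic ring of carbon only) in place of a group of 11 heavy atoms (8 carbon, 2 oxygen, 1 bromine; one six-membered aromatic ring of carbon only), on an aromatic carbon. The rest of compound 1, including its amine-bearing side chain, stays as it is.

Going by the values given here, none of the measured steps covers this change directly. Among the compounds with values here, the single measured step, a 59-fold lower number from compound 2 to compound 3 (1.77 log units; beyond the scatter), concerns the amine side chain and not the bridge. Compounds 2 and 3 both carry the same kind of bridge that compound 4 gains, and both give lower numbers than compound 1, but they also differ from compound 1 in their side chains, so the two changes cannot be separated on these data. Because compound 2 gives 190 nM with that bridge, a modest move toward lower numbers is expected for compound 4, a 2.6-fold lower number from compound 1 to compound 4 (0.41 log units; beyond the scatter), with wide uncertainty.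

Compound 4 is therefore estimated at 350 nM in this assay, with a range from 70 nM to 1500 nM.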

Compound 4, inhibition constant: 4.3 nM
Estimate against measurement, compound 4: 81-fold (1.91 log units) above, outside the stated range (below it).
By their numbers in this assay, from the lowest: compounds 3 and 4 (each within the scatter of the next); then compound 2; then compound 1.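

In this assay, exchanging the leaving group on this aromatic carbon, ortho to a fluoro group, for 2-(5-bromo-2-methoxyphenyl)ethyl gives a 210-fold lower number from compound 1 to compound 4 (2.32 log units; beyond the scatter), and the step lies well beyond the scatter. This is the first pair shown in which the bridge alone changes while the amine-bearing side chain stays the same, so this position matters a great deal in its own right, and the side chain is not the only part that can shift the number strongly. The two groups have the same count of heavy atoms and the same kind of ring, yet the change from 8 carbon and 2 oxygen to 9 carbon and 1 oxygen, with 2 hydrogen-bond acceptors giving way to 1, goes with this large step, and nothing shown here explains why.

From the compounds shown here alone, whether the bridge change has a similar size with other side chains remains open, since an oxygen-bridged partner of compound 2 or compound 3 would be needed to tell. Also open, going by these compounds, is how a sulfur atom or an amine nitrogen in place of the bridge oxygen, or a longer carbon bridge, would compare.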